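This account rests on a few compounds, and the source may have more. Where it says the series, first, only, none or still open, it means among the compounds named here.

Measured in a functional assay on MCF7 cells (Homo sapiens) for cytotoxicity, read by MTT assay, with a stated time of 72 h; on this read-out lower numbers stand for stronger inhibition and higher numbers for weaker inhibition:
- Compound 1 `O=C(N/N=C/c1ccc(F)cc1Cl)Nc1cc2c(Nc3ccc(F)c(Cl)c3)ncnc2cc1O[C@H]1CCOC1`: 32200 nM
- Compound 2 `COc1cc(/C=N/NC(=O)Nc2cc3c(Nc4ccc(F)c(Cl)c4)ncnc3cc2O[C@H]2CCOC2)cc(OC)c1OC`: 26500 nM
- Compound 3 `O=C(N/N=C/c1cc(Br)c(O)c(Br)c1)Nc1cc2c(Nc3ccc(F)c(Cl)c3)ncnc2cc1O[C@H]1CCOC1`: 5910 nM

Compound 1 stands at the high, weaker end of these three numbers. Exchanging its ring gives a 1.2-fold lower number from compound 1 to compound 2 (0.08 log units; within the scatter), but also a 5.4-fold lower number from compound 1 to compound 3 (0.74 log units; beyond the scatter). Compound 4 `O=C(N/N=C/c1ccc(O)cc1O)Nc1cc2c(Nc3ccc(F)c(Cl)c3)ncnc2cc1O[C@H]1CCOC1` keeps the core of compound 1 and carries 2,4-dihydroxyphenyl in place of 2-chloro-4-fluorophenyl on a carbon with a double bond to nitrogen.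

Both measured steps changed this same ring, so they are the best available guide. For the measured compounds named here, compound 3, the only measured compound with a hydroxy group on this ring, gives 5910 nM. However, it also carries two bromines, which compound 4 lacks, so only part of that step may carry over. A small move towards a lower number in this assay is therefore expected, possibly no larger than the scatter. The estimated change is a 2.1-fold lower number from compound 1 to compound 4 (0.33 log units; beyond the scatter). For compound 4 the estimate is 15000 nM, with an expected range from 5000 nM to 40000 nM.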

Compound 4, half-maximal inhibitory concentration: 5350 nM
Compound 4: middle estimate off by 2.8-fold (0.45 log units), on the high side, within the range that was stated.
By their numbers in this assay, from the lowest: compounds 4 and 3 (each within the scatter of the next); then compounds 2 and 1 (each within the scatter of the next).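

In this assay, the change to 2,4-dihydroxyphenyl gives a 6.0-fold lower number from compound 1 to compound 4 (0.78 log units; beyond the scatter) and a 5.0-fold lower number from compound 2 to compound 4 (0.69 log units; beyond the scatter), so a ring with hydroxy groups and no halogen can reach the low end of this small set. The comparison of the two hydroxy-bearing rings gives a 1.1-fold lower number from compound 3 to compound 4 (0.04 log units; within the scatter), which shows that the two bromines of compound 3 are not required to reach a number at this level. No measurement shown here accounts for these steps.

On these data alone, it remains open whether a single hydroxy group on an otherwise unsubstituted phenyl would give a similar number, and whether an amine or a carboxylic acid could take the place of the hydroxy groups. All of these compounds also share the core of compound 1, so the effect of this ring change on a different core cannot be judged.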